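A few compounds are considered here, and "the series" means these few. Any claim that something is new, unique, unknown or untested is made for them only; others in the source may bear on it.

Measured so far in a functional assay on A549 cells (Homo sapiens) for inhibition, read by MTT assay, with a stated time of 72 h; a higher number here means a weaker inhibitor, a lower number a stronger inhibitor:
- compound 1 `COC(=O)c1ccc(-n2cc(CCCc3nnc(-c4ccc(C)cc4)o3)nn2)cc1`: 65100 nM
- compound 2 `Cc1ccc(NC(=S)CCCn2cc(-c3ccc(C(F)(F)F)cc3)nn2)cc1`: 5500 nM

Of these two compounds, compound 2 is the stronger inhibitor. Its value of 5500 nM is the lower number, and the gap to compound 1 at 65100 nM lies beyond the usual scatter of repeated measurements. The two structures differ in more than one place, however, so this gap cannot be traced to any single group.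

The next compound, compound 3 `FC(F)(F)c1ccc(-c2cn(CCCC(=S)Nc3ccc(-c4ccccc4)cc3)nn2)cc1`, has not yet been measured in this assay. It keeps the structure of compound 2 except for one change: phenyl in place of methyl on an aromatic carbon, para to a large group (phenyl in place of methyl on an aromatic carbon). For the measured compounds named here, no measured pair tests this kind of swap, so the data offer no direction for it. The expectation therefore stays close to compound 2 at 5500 nM, with no shift beyond the scatter. The expected change is a 1.4-fold lower number from compound 2 to compound 3 (0.14 log units; within the scatter), and this is only an estimate. Compound 3 is estimated at 4000 nM, with an expected range of 1200 nM to 15000 nM.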

Compound 3, half-maximal inhibitory concentration: 1000 nM
The estimate for compound 3 lay 4.0-fold (0.60 log units) above the measured number, outside the stated range (below it).
By their numbers in this assay, from the lowest: compound 3; then compound 2; then compound 1.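

In this assay, for the compounds shown here, phenyl in place of methyl on an aromatic carbon, para to a large group, gives a 5.5-fold lower number from compound 2 to compound 3 (0.74 log units; beyond the scatter) as the only step that can be read so far. This shows that the number at this position can respond to the group placed there, and that a group of 6 heavy atoms in place of 1 heavy atom is compatible with a lower number, with the rest of compound 2 unchanged. The two groups count 0 hydrogen-bond donors and 0 hydrogen-bond acceptors each, and nothing available explains why the number falls.

One step cannot show whether the ring itself matters or whether any larger group at this carbon would do the same, and an ethyl group, a cyclohexyl ring or a pyridine ring there would help to separate these readings. From the compounds shown here alone, it also remains open whether a chlorine atom or a methoxy group would keep the number near that of compound 3, and whether phenyl would give a similar step with a group other than trifluoromethyl on the far ring.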